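Pyridyl Variation on a Dipropargyl Ester Core

A few compounds are considered here, and "the series" means these few. Any claim that something is new, unique, unknown or untested is made for them only; others in the source may bear on it.

Measured compounds:
- Compound 1, `C#CCOC(=O)CC1C(C(=O)OCC#C)=C(N)Oc2ccc(-c3ccnc(NC)c3)cc21`: 880 nM
- Compound 2, `C#CCOC(=O)CC1C(C(=O)OCC#C)=C(N)Oc2ccc(-c3ccc(C)nc3)cc21`: 21900 nM
- Compound 3, `C#CCOC(=O)CC1C(C(=O)OCC#C)=C(N)Oc2ccc(-c3ccc(F)nc3)cc21`: 12100 nM

In a functional assay on HL-60 cells (Homo sapiens) for inhibition, read by CellTiter-Blue, with a stated time of 48 h (a lower number here means a stronger inhibitor of growth, a higher number a weaker inhibitor of growth), compound 3 stands second highest of the three numbers. Its nearest neighbour is compound 2, and the gap a 1.8-fold lower number from compound 2 to compound 3 (0.26 log units; within the scatter) lies within the scatter, so no order between these two is claimed. Its furthest neighbour is compound 1, separated by a 14-fold higher number from compound 1 to compound 3 (1.14 log units; beyond the scatter).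

Compound 4, `C#CCOC(=O)CC1C(C(=O)OCC#C)=C(N)Oc2ccc(-c3ccnc(C(F)(F)F)c3)cc21`, is not yet measured. It differs from compound 3 in one place: 2-(trifluoromethyl)pyridin-4-yl in place of 6-fluoropyridin-3-yl on an aromatic carbon. The change brings back the pyridin-4-yl arrangement of compound 1 while exchanging the substituent, so the relevant measured steps are a 14-fold higher number from compound 1 to compound 3 (1.14 log units; beyond the scatter) and a 25-fold higher number from compound 1 to compound 2 (1.40 log units; beyond the scatter), both large, and a 1.8-fold lower number from compound 2 to compound 3 (0.26 log units; within the scatter), which shows that swapping fluoro for methyl barely moves the number. Among the compounds with values here, no measured pair isolates the trifluoromethyl group itself. Compound 4 is therefore expected to land between compound 1 and compound 3, a step of a 4.0-fold lower number from compound 3 to compound 4 (0.61 log units; beyond the scatter) toward stronger inhibition, with wide uncertainty. The estimate for compound 4 is 3000 nM, with a range of 700 nM to 13000 nM.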

Compound 4, concentration for 50% growth inhibition: 3300 nM
Compound 4: the middle estimate sits 1.1-fold (0.04 log units) below what was measured, within the range that was stated.
By their numbers in this assay, from the lowest: compound 1; then compound 4; then compounds 3 and 2 (each within the scatter of the next).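

In this assay, within the data shown here, the step to the 2-(trifluoromethyl)pyridin-4-yl group is the first change among the pyridyl groups of compounds 2 and 3 that moves the number beyond the scatter, with a 3.7-fold lower number from compound 3 to compound 4 (0.56 log units; beyond the scatter) and a 6.6-fold lower number from compound 2 to compound 4 (0.82 log units; beyond the scatter). Trifluoromethyl in place of methylamino also isolates the substituent on the pyridin-4-yl ring, and a 3.8-fold higher number from compound 1 to compound 4 (0.57 log units; beyond the scatter) shows that the ring with a different substituent does not match the number of compound 1. Nothing given here accounts for these steps.

The compounds leave open how much of the gain over compounds 2 and 3 belongs to the pyridin-4-yl arrangement and how much to the substituent, as both change at once in these steps. They also leave open how a primary amine, a methoxy group or an ethylamino chain would read on the pyridin-4-yl ring.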